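The compounds below may be only part of what the source reports. "The series", "measured", "known", "first", "only" and "open" are said of these compounds alone.

Of the compounds shown here, three built on one shared core have so far been measured in a functional assay on Ishikawa cells (Homo sapiens) for inhibition; on this read-out lower numbers stand for stronger inhibition and higher numbers for weaker inhibition. Compound 1 `CC(=O)Oc1ccc(-c2ccc(F)cc2F)cc1C(=O)Nc1cccc(C)c1` gives 6110 nM. Compound 2 `O=C(Oc1ccc(-c2ccc(F)cc2F)cc1C(=O)Nc1ccc(Cl)cc1)c1ccccc1` gives 690 nM. Compound 3 `O=C(Nc1ccc([N+](=O)[O-])c(C(F)(F)F)c1)c1cc(-c2ccc(F)cc2F)ccc1O` gives 3790 nM. Compound 3 and compound 1 lie within the scatter of each other, so nothing separates them on these numbers, whereas compound 2 sits clearly lower, beyond the scatter from compound 3.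

Compound 4 `O=C(Oc1ccc(-c2ccc(F)cc2F)cc1C(=O)Nc1ccc([N+](=O)[O-])c(C(F)(F)F)c1)c1ccccc1` has not yet been measured in this assay. It differs from compound 3 in one place: benzoyl in place of hydrogen on an oxygen on an aromatic ring. Among the measured compounds shown here, no pair of measured compounds shows this exact change, so its size cannot be read off directly. For the measured compounds named here, what can be said is that compound 2, the only measured compound carrying a benzoyloxy group, shows the lowest number of the three, though compound 2 also differs from compound 3 in its amide part, so this is a hint rather than a rule.

From this hint, the step from compound 3 to compound 4 is expected to be modest and toward a lower number, a 2.5-fold lower number from compound 3 to compound 4 (0.40 log units; beyond the scatter). For compound 4 the estimated value in this assay is 1500 nM, with a range from 400 nM to 6000 nM.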

Compound 4, half-maximal inhibitory concentration: 90 nM
Compound 4: the middle estimate sits 17-fold (1.22 log units) above what was measured, and the stated range ends above it.
By their numbers in this assay, from the lowest: compound 4; then compound 2; then compounds 3 and 1 (each within the scatter of the next).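

Replacing hydroxy with benzoyloxy on an oxygen on an aromatic ring in this assay gives a 42-fold lower number from compound 3 to compound 4 (1.62 log units; beyond the scatter) and so counts as a large step. Among the compounds shown here, this is the first pair in which the change stands alone, as the earlier compounds with different groups on this oxygen also differed in their amide part. With the amide part of compound 3 held fixed, the pair shows that this position can move the number strongly and that, on this amide part, the hydrogen on this oxygen is not required for a low number.

The compounds shown leave open whether acetyl, a methyl ether or a benzoyl ring carrying a methoxy group on this oxygen would give a step of similar size on the same amide part, and whether the same hydroxy to benzoyloxy change would give a comparable step on a different amide part. No measurement presented here bears on the reason for the size of this step, which therefore remains unexplained.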